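Swapping the aryl group on the amide of compound 2

The source may hold more compounds than are shown below. What is called first, only, known or untested is meant among the compounds shown, and "the series" means these compounds.

Compound 1, `Cc1cc(N(C)C)nc2ccc(NC(=O)c3ccc(Cl)c(Cl)c3)cc12`, gives 33300 nM in a functional assay on MCF7 cells (Homo sapiens) for antiproliferative activity, read by MTT assay, with a stated time of 72 h; on this read-out lower numbers stand for stronger inhibition and higher numbers for weaker inhibition. Compound 2, `CCN1CCN(c2cc(C)c3cc(NC(=O)c4cccc(F)c4)ccc3n2)CC1`, gives 8920 nM in this assay. Compound 3, `Cc1cc(NCCN2CCCC2)nc2ccc(NC(=O)c3ccc(Cl)c(Cl)c3)cc12`, gives 1280 nM in this assay.

Compound 2 stands second highest of the three numbers in this assay: compound 1 gives a higher number and compound 3 a lower one, both gaps beyond the scatter. Compound 4, `CCN1CCN(c2cc(C)c3cc(NC(=O)c4ccc(C)cc4)ccc3n2)CC1`, differs from compound 2 by 4-methylphenyl in place of 3-fluorophenyl on a carbonyl carbon. Within the data shown here, the only measured step, a 26-fold lower number from compound 1 to compound 3 (1.42 log units; beyond the scatter), alters the amino group on the shared core rather than the aryl group on the carbonyl, so it does not bear on this change, and no measured pair varies that aryl group. The step from compound 2 is therefore expected to be a 1.0-fold higher number from compound 2 to compound 4 (0.00 log units; within the scatter), with no direction expected beyond the scatter. Compound 4 is estimated at 9000 nM, within 3000 nM to 27000 nM.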

Compound 4, half-maximal inhibitory concentration: 6740 nM
The estimate for compound 4 lay 1.3-fold (0.13 log units) above the measured number; measured number inside the range.
By their numbers in this assay, from the lowest: compound 3; then compounds 4 and 2 (each within the scatter of the next); then compound 1.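

Swapping the aryl group on the carbonyl carbon gives the first measured step at this position: in this assay, 4-methylphenyl in place of 3-fluorophenyl gives a 1.3-fold lower number from compound 2 to compound 4 (0.12 log units; within the scatter) and so stays within the scatter. The earlier step, a 26-fold lower number from compound 1 to compound 3 (1.42 log units; beyond the scatter), changed the amino group on the shared core and left this position untouched. No measurement at hand explains why these two aryl groups read alike. On these data alone, it remains open whether an amine or a carboxylic acid on this aryl ring would move the number.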